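Selenium series: removing the aryl methoxy of compound 3

A few compounds are considered here, and "the series" means these few. Any claim that something is new, unique, unknown or untested is made for them only; others in the source may bear on it.

Three compounds have numbers in a functional assay on Jurkat cells (Homo sapiens) for cytotoxicity, read by MTT assay, with a stated time of 24 h; on this read-out lower numbers stand for an effect already at smaller amounts and higher numbers for an effect only at larger amounts of compound. Compound 1 `CCCCC#Cc1cc(C(=O)OCC)nc2ccc(OC)cc12` gives 15900 nM. Compound 2 `CCOC(=O)c1cc([Se]c2ccccc2)c2cc(C)ccc2n1` gives 15300 nM. Compound 3 `CCOC(=O)c1cc([Se]c2ccc(OC)cc2)c2cc(OC)ccc2n1` gives 82500 nM, the highest of the three; compound 1 and compound 2 both sit at lower numbers, and both gaps lie beyond the scatter. No two of these compounds differ in only one place, so no single step can be read off the measured set.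

Compound 4 `CCOC(=O)c1cc([Se]c2ccccc2)c2cc(OC)ccc2n1` has not been measured in this assay. It differs from compound 3 in one place: hydrogen in place of methoxy on an aromatic carbon. Within the data shown here, the measured set holds no direct precedent for this change, so the expectation rests on the range spanned by the three numbers above.

The step of a 2.4-fold lower number from compound 3 to compound 4 (0.37 log units; beyond the scatter) is expected to run toward a lower number and to land just beyond the scatter, because compound 2 at 15300 nM shows that a compound of this series carrying the plain phenyl group can reach a far lower number than compound 3. Compound 4 is estimated at 35000 nM, within a range from 12000 nM to 90000 nM.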

Compound 4, half-maximal effective concentration: 102000 nM
The estimate for compound 4 lay 2.9-fold (0.46 log units) below the measured number, outside the stated range (above it).
By their numbers in this assay, from the lowest: compounds 2 and 1 (each within the scatter of the next); then compounds 3 and 4 (each within the scatter of the next).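

In this assay the change from 4-methoxyphenyl to phenyl gives a 1.2-fold higher number from compound 3 to compound 4 (0.09 log units; within the scatter) and so leaves no readable effect of this methoxy on the aromatic carbon para to a large group. With the plain phenyl group held, methoxy in place of methyl on an aromatic carbon gives a 6.7-fold higher number from compound 2 to compound 4 (0.82 log units; beyond the scatter) and shows that the plain phenyl group alone does not bring the low number of compound 2. The step of a 6.4-fold higher number from compound 1 to compound 4 (0.81 log units; beyond the scatter) comes with a group of 7 heavy atoms in place of a group of 6 heavy atoms on an aromatic carbon, so that exchange also moves the number beyond the scatter.

Still open, as far as these compounds go, is whether an amine or a carboxylic acid in place of the methoxy of compound 3 would change the number. No measurement shown explains any of these steps.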